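Swapping 3-nitrophenyl for 4-aminophenyl in compound 3

A few compounds are considered here, and "the series" means these few. Any claim that something is new, unique, unknown or untested is made for them only; others in the source may bear on it.

Compound 1 `COc1cc(C(=O)c2cn(-c3ccccc3)cc2-c2ccc(N)cc2)cc(OC)c1OC` gives 9 nM
Compound 2 `COc1cc(C(=O)c2cn(-c3cccc(C)c3)cc2-c2ccccc2[N+](=O)[O-])cc(OC)c1OC` gives 220 nM
Compound 3 `COc1cc(C(=O)c2cn(-c3cccc(C)c3)cc2-c2cccc([N+](=O)[O-])c2)cc(OC)c1OC` gives 880 nM

These three numbers come from a functional assay on MCF7 cells (Homo sapiens) for cytotoxicity, read by MTT assay, with a stated time of 96 h (a lower number here means a stronger inhibitor, a higher number a weaker inhibitor), and compound 3 has the highest of them. Compound 4 `COc1cc(C(=O)c2cn(-c3cccc(C)c3)cc2-c2ccc(N)cc2)cc(OC)c1OC` keeps the shared core and the 3-methylphenyl group of compound 3 and differs in one place 4-aminophenyl in place of 3-nitrophenyl on an aromatic carbon where 4-aminophenyl stands in place of 3-nitrophenyl on an aromatic carbon.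

Within the data shown here, only one measured step touches this group. Putting 3-nitrophenyl in place of 2-nitrophenyl gave a 4.0-fold higher number from compound 2 to compound 3 (0.60 log units; beyond the scatter) as a modest change, which shows that the number can shift with this group, although no amine is involved. A closer guide is compound 1, which carries the same 4-aminophenyl group with a plain phenyl where compound 4 has its 3-methylphenyl group. Compound 1 gives 9 nM and so points to a step much larger than the nitro one, toward a lower number. Among the measured compounds shown here, no measured pair shows what the methyl does alongside 4-aminophenyl, so the expectation stays wide. The estimated change is a 59-fold lower number from compound 3 to compound 4 (1.77 log units; beyond the scatter) in this assay as a clear gain in strength. For compound 4 the expected value is 15 nM with an estimated range from 4 nM to 60 nM around it.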

Compound 4, half-maximal inhibitory concentration: 18 nM
Estimate against measurement, compound 4: 1.2-fold (0.08 log units) below, within the range that was stated.
By their numbers in this assay, from the lowest: compounds 1 and 4 (each within the scatter of the next); then compound 2; then compound 3.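

In this assay the group on this aromatic carbon turns out to matter far more than the two nitro compounds alone could show: 4-aminophenyl in place of 3-nitrophenyl gives a 49-fold lower number from compound 3 to compound 4 (1.69 log units; beyond the scatter) and 4-aminophenyl in place of 2-nitrophenyl gives a 12-fold lower number from compound 2 to compound 4 (1.09 log units; beyond the scatter) in the same series. Both steps are larger than a 4.0-fold higher number from compound 2 to compound 3 (0.60 log units; beyond the scatter) seen when only the nitro group changes its place on the phenyl ring, although each of them alters the group and its place on that ring together. The other place also now has a direct reading alongside 4-aminophenyl, since methyl in place of hydrogen gives a 2.0-fold higher number from compound 1 to compound 4 (0.30 log units; within the scatter) and so leaves compound 1 and compound 4 indistinguishable in this assay.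

The compounds shown leave open whether the gain follows the amine itself or its place on the ring, a question that 4-nitrophenyl, 3-aminophenyl or 2-aminophenyl on the same carbon would help to separate. No measurement is available that gives a reason for the size of these steps.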